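Removing an Acid Group in a Cell Cytotoxicity Series

The compounds below may be only part of what the source reports. "The series", "measured", "known", "first", "only" and "open" are said of these compounds alone.

Of the compounds shown here, two from one series have been measured in an ADME assay on U-937 cells (Homo sapiens) for cytotoxicity, read by MTT assay, with a stated time of 24 h, tested at 80 uM; on this read-out lower numbers stand for a stronger effect and higher numbers for a weaker effect at the one concentration tested. Compound 1 `CCCCCc1cc(O)cc(O)c1Oc1cc2c(cc1OC)C(O)(CCCC)OC2=O` gives 114% in this assay, a number that means the cells were left essentially unharmed. Compound 2 `CCCCCc1c(Oc2cc3c(cc2OC)C(CCCC)(OC)OC3=O)c(O)cc(O)c1C(=O)O` gives 52% in this assay, the lowest of the two numbers and the stronger effect; its gap to compound 1 lies well beyond the usual scatter. Compound 3 `CCCCCc1cc(O)cc(O)c1Oc1cc2c(cc1OC)C(CCCC)(OC)OC2=O` is the next compound to be measured. It differs from compound 2 in one place: hydrogen in place of carboxy on an aromatic carbon. Among the measured compounds shown here, no step between two measured compounds isolates this change, so any expectation rests on the two values that exist. Compound 1, which likewise carries no carboxy group, shows a weak effect, while compound 2 with the carboxy shows a stronger one. An upward step, toward a weaker effect and beyond the scatter, is therefore expected: a number 40 percentage points higher from compound 2 to compound 3 (beyond the scatter). Compound 3 is estimated to give 92% in this assay, within a range from 58% to 120%.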

Compound 3, a percentage reported as activity, at one concentration (the size of the read-out at that concentration, not a potency): 24%
Compound 3: the middle estimate sits 68 percentage points above what was measured, and the stated range ends above it.
By their numbers in this assay, from the lowest: compound 3; then compound 2; then compound 1.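

Putting hydrogen in place of carboxy on this aromatic carbon, ortho to a hydroxy group and ortho to a pentyl group, gives (a number 28 percentage points lower from compound 2 to compound 3 (beyond the scatter)), so in this assay the effect on the cells grows stronger when the carboxy group leaves. The carboxy group is therefore not required for the effect in this series, and compound 3 reaches the lowest number of the three without it. The second single change, methyl in place of hydrogen on an oxygen on a saturated carbon, gives (a number 90 percentage points lower from compound 1 to compound 3 (beyond the scatter)), so this small change on the other side of the molecule separates a compound that leaves the cells unharmed from the most active one shown.

Nothing available explains why either change moves the number in this way. On these data alone, what remains open is whether the trend holds for other groups, such as a methyl ester or an amide on the aromatic carbon or an ethyl group on the oxygen, and how these compounds would behave at concentrations other than the single one tested.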